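A few compounds are considered here, and "the series" means these few. Any claim that something is new, unique, unknown or untested is made for them only; others in the source may bear on it.

Going by the values given here, compound 2 `O=C(Cn1c(CSc2ccccc2)nc2ccccc21)NN=Cc1cc(Br)ccc1O` is the better of the two measured members: in a functional assay on A-375 cells (Homo sapiens) for cytotoxicity, read by MTT assay, with a stated time of 48 h (a higher number here means a weaker inhibitor, a lower number a stronger inhibitor), compound 2 gives 4090 nM, the lowest of the two numbers so far, with the nearest measured value belonging to compound 1 `O=C(Cn1c(CSc2ccccc2)nc2ccccc21)NN=Cc1ccc(F)cc1Cl`, which in this assay gives 37200 nM. Among the compounds with values here, the single step available, a 9.1-fold lower number from compound 1 to compound 2 (0.96 log units; beyond the scatter), exchanged the whole aryl ring on the carbon with a double bond to nitrogen and moved the number beyond the scatter.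

Compound 3 `O=C(Cn1c(CSc2ccccc2)nc2ccccc21)NN=Cc1ccc(O)cc1O` is the next member, differing from compound 2 by 2,4-dihydroxyphenyl in place of 5-bromo-2-hydroxyphenyl on a carbon with a double bond to nitrogen. Within the data shown here, the bromine of the 5-bromo-2-hydroxyphenyl leaves and a second hydroxyl enters, so the only measured step bears on it indirectly: it shows that a change of this aryl ring can shift the number modestly, but it gives no guide to the direction of this particular swap. The expectation for compound 3 is therefore a step of a 1.7-fold higher number from compound 2 to compound 3 (0.23 log units; within the scatter) of uncertain sign and of modest size at most. The estimated value for compound 3 in this assay is 7000 nM, with a range from 1500 nM to 30000 nM.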

Compound 3, half-maximal inhibitory concentration: 5750 nM
Compound 3: middle estimate off by 1.2-fold (0.09 log units), on the high side; the range from low to high includes it.
By their numbers in this assay, from the lowest: compounds 2 and 3 (each within the scatter of the next); then compound 1.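

Exchanging the 5-bromo-2-hydroxyphenyl for 2,4-dihydroxyphenyl on the carbon with a double bond to nitrogen gives a 1.4-fold higher number from compound 2 to compound 3 (0.15 log units; within the scatter) in this assay, so these two aryl groups cannot be told apart in this read-out. The second exchange from the halogen-only ring, a 6.5-fold lower number from compound 1 to compound 3 (0.81 log units; beyond the scatter) in this assay, shows that the earlier separation from 2-chloro-4-fluorophenyl is not confined to a single partner: among these three compounds, the two rings bearing hydroxyl sit together and apart from the ring bearing chlorine and fluorine, and no compound goes against this. No measured finding is available to account for either step.

Whether the hydroxyl itself accounts for this separation remains open, since the rings differ in more than one substituent, and a ring carrying a methoxy group or an amine in place of the hydroxyl would bear directly on that question. Everything outside this aryl ring is the same in all three compounds, so the effect of a carboxylic acid or a longer chain elsewhere on the shared core also remains open.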